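The compounds below may be only part of what the source reports. "The series", "measured", "known", "first", "only" and "open" are said of these compounds alone.

Compound 1 `CCS(=O)(=O)N(Cc1cccnc1)c1ccc(C(O)c2ccccc2)cc1`: > 30000 nM
Compound 2 `CCS(=O)(=O)N(Cc1cccnc1)c1cccc(C(O)c2ccccc2)c1`: 2500 nM
Compound 3 `CCS(=O)(=O)N(Cc1cccnc1)c1cccc(C(=O)c2ccccc2)c1`: 1100 nM

Of the compounds shown here, three have been measured in an assay on isolated protein with metabotropic glutamate receptor 2 (Homo sapiens) as the target; on this read-out lower numbers stand for an effect already at smaller amounts and higher numbers for an effect only at larger amounts of compound. Compound 1 reaches only a limit of the assay, > 30000 nM, so no number is known for it. Compound 2 gives 2500 nM in this assay. Compound 3 gives 1100 nM. Compound 1 therefore stands at the weak end of the set, at the limit (the limit of > 30000 nM in this assay, at which 1 of the 3 values shown sits).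

One measured step joins compounds that differ in a single place: a 2.3-fold lower number from compound 2 to compound 3 (0.36 log units; beyond the scatter). It shows that exchanging the hydroxy(phenyl)methyl group for a carbonyl-bearing group moved the number only modestly.

Compound 4 `C=C(c1ccccc1)c1ccc(N(Cc2cccnc2)S(=O)(=O)CC)cc1` has not been measured. It differs from compound 1 in one place: 1-phenylethenyl in place of hydroxy(phenyl)methyl on an aromatic carbon. The step from compound 2 to compound 3 bears on it only loosely, since the entering group here carries a double bond rather than a carbonyl, and the change sits para to a large group, where compound 1 showed only a limit. A modest movement at most is expected, and a limit is a real possibility.

Compound 4 is expected to give about 25000 nM in this assay, with a range from 6000 nM to 100000 nM. That estimate corresponds to a step of an at least 1.2-fold lower number from compound 1 to compound 4 (0.07 log units; that floor lies within the scatter).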

Compound 4, half-maximal effective concentration: 780 nM
For compound 4 the middle estimate is 32-fold (1.51 log units) above the measured one, outside the stated range (below it).
By their numbers in this assay, from the lowest: compounds 4 and 3 (each within the scatter of the next); then compound 2. At a limit, above all of these: compound 1.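

In this assay, 1-phenylethenyl in place of hydroxy(phenyl)methyl gives an at least 38-fold lower number from compound 1 to compound 4 (1.58 log units; beyond the scatter), so this place, para to a large group, can carry a group that gives a measurable number, which compound 1 alone could not show. The earlier exchange of the same leaving group for benzoyl, a 2.3-fold lower number from compound 2 to compound 3 (0.36 log units; beyond the scatter), moved the number only modestly, whereas this exchange, between two groups that each hold 8 heavy atoms and one six-membered aromatic ring of carbon only, has a large effect. Compound 1 stands at a limit, so this step has only a floor and its full size cannot be read: the limit of > 30000 nM in this assay, at which 1 of the 4 values shown sits.

The compounds shown leave open whether the lower number goes with losing the hydroxy group or with gaining the double bond; benzoyl or a plain benzyl group at this place would help to separate the two. Also open, on these data alone, is whether 1-phenylethenyl would have a similar effect at the place it occupies in compound 2, and whether an amine or a longer chain would be tolerated para to the large group.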